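The source may hold more compounds than are shown below. What is called first, only, known or untested is meant among the compounds shown, and "the series" means these compounds.

In a functional assay on MGC-803 cells (Homo sapiens) for inhibition, read by MTT assay, with a stated time of 72 h (on this read-out lower numbers stand for stronger inhibition and higher numbers for weaker inhibition), three compounds sharing one core have been measured so far. Compound 1 (`C#CCSc1nc(NCCC(C)C)c2ccncc2n1`) gives > 80000 nM as a limit of the assay and not a number. Compound 2 (`C#CCSc1nc(NCCC#N)c2ccncc2n1`) likewise gives > 80000 nM as a limit and not a number. Within the data shown here, compound 3 (`C#CCSc1nc(Nc2ccccc2Cl)c2ccncc2n1`) gives 27600 nM and so holds the only true number of the three.

Compound 4 (`C#CCSc1nc(Nc2ccc(Cl)cc2)c2ccncc2n1`) has 4-chlorophenyl in place of 2-chlorophenyl on a nitrogen on an aromatic ring. Among the measured compounds shown here, two measured steps bear on this change, both only loosely. They are an at least 2.8-fold lower number from compound 1 to compound 3 (0.46 log units; beyond the scatter) and an at least 2.8-fold lower number from compound 2 to compound 3 (0.46 log units; beyond the scatter) and each puts 2-chlorophenyl in place of a chain. Neither compares two chlorophenyl groups. With compound 3 at 27600 nM as the anchor, no step beyond the scatter is expected in this assay for this move. The estimated step is a 1.1-fold higher number from compound 3 to compound 4 (0.04 log units; within the scatter) and it could fall in either direction. Compound 4 is expected at 30000 nM with an estimated range of 12000 nM to 75000 nM in this assay overall.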

Compound 4, half-maximal inhibitory concentration: 16400 nM
Beside the measured number, compound 4's estimate is 1.8-fold (0.26 log units) above it, within the range that was stated.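

In this assay, shifting the chlorine on the phenyl ring gives a 1.7-fold lower number from compound 3 to compound 4 (0.23 log units; within the scatter), so 2-chlorophenyl and 4-chlorophenyl cannot be told apart on this nitrogen. The new group also reads lower than both chains, with an at least 4.8-fold lower number from compound 2 to compound 4 (0.68 log units; beyond the scatter) and an at least 4.8-fold lower number from compound 1 to compound 4 (0.68 log units; beyond the scatter), so a second chlorophenyl group now stands apart from 2-cyanoethyl and isopentyl. Those two steps give only minimum sizes, since compound 1 and compound 2 each rest on a limit of the assay and not a number: the limit of > 80000 nM in this assay, at which 2 of the 4 values shown sit.

From the compounds shown here alone, it remains open whether a plain phenyl ring, with no chlorine, would read the same as these two groups. Going by these compounds, it is also open whether a methoxy group or a carboxylic acid in place of the chlorine would shift the number beyond the scatter.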